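An allyl chain in place of propyl on the shared core

A few compounds are considered here, and "the series" means these few. Any claim that something is new, unique, unknown or untested is made for them only; others in the source may bear on it.

Compound 2 `CCCc1c(OC)nc2nc(-c3nnc(C)o3)cn2c1C` carries a propyl chain on the shared core. Going by the values given here, in a functional assay on the whole organism with Rattus norvegicus as the target (a higher number here means that more compound is needed for the effect, a lower number that less compound is needed), compound 2 gives 10 mg/kg, the higher of the two numbers known so far. Among the compounds with values here, its nearest neighbour is compound 1 `CCc1c(OC)nc2nc(-c3nnc(C)o3)cn2c1C`, which in this assay gives 2 mg/kg, so that a 5.0-fold higher number from compound 1 to compound 2 (0.70 log units; beyond the scatter) is the only step measured to date, and it runs in the direction of more compound being needed when the chain grows.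

Compound 3 `C=CCc1c(OC)nc2nc(-c3nnc(C)o3)cn2c1C` is the next compound, not yet measured. Its difference from compound 2 is vinyl in place of ethyl on a saturated chain carbon bound to an aromatic carbon, which, read one bond further out, is propyl to allyl. The chain therefore keeps its length; only the double bond enters. Within the data shown here, no measured step tells how a double bond in this chain behaves, and the one step known, from ethyl to propyl, concerns length rather than saturation. The expectation is therefore a step of a 1.3-fold lower number from compound 2 to compound 3 (0.10 log units; within the scatter), within the scatter, and compound 3 is estimated to give 8 mg/kg in this assay, with a range from 3 mg/kg to 25 mg/kg.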

Compound 3, minimum effective dose: 10 mg/kg
The estimate for compound 3 lay 1.3-fold (0.10 log units) below the measured number; measured number inside the range.
By their numbers in this assay, from the lowest: compound 1; then compounds 2 and 3 (each within the scatter of the next).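

In this assay, bringing a double bond into the chain gives no measurable shift (no change at the digits printed from compound 2 to compound 3 (within the scatter)), so on a saturated chain carbon bound to an aromatic carbon, the propyl and allyl chains cannot be told apart by this read-out. The step from the ethyl chain to the allyl chain (a 5.0-fold higher number from compound 1 to compound 3 (0.70 log units; beyond the scatter)) matches the one from the ethyl chain to the propyl chain (a 5.0-fold higher number from compound 1 to compound 2 (0.70 log units; beyond the scatter)), which shows that the higher number seen with propyl also appears with an unsaturated chain. Nothing available explains either step or the absence of a change between propyl and allyl.

From the compounds shown here alone, it remains open whether a longer chain such as butyl, a branched chain such as isopropyl, or a propargyl chain with its triple bond would stay with propyl and allyl in this assay, and whether a methyl group or a bare hydrogen here would fall below compound 1. Also open, going by these compounds, is whether an amine or a hydroxyl group carried on the chain would move the number in either direction.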